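The source may hold more compounds than are shown below. What is called first, only, known or untested is meant among the compounds shown, and "the series" means these compounds.

Measured in a functional assay on HL-60 cells (Homo sapiens) for cytotoxicity, read by WST assay, with a stated time of 48 h; a higher number here means that more compound is needed for the effect, a lower number that less compound is needed:
compound 1 `O=C1OC[C@H](Cc2ccccc2)[C@H]1Cc1ccccc1OC(F)(F)F`, 39000 nM
compound 2 `O=C1OC[C@H](Cc2ccccc2)[C@H]1Cc1ccccc1F`, 72000 nM

Compound 2 sits level with compound 1 in this assay: a 1.8-fold higher number from compound 1 to compound 2 (0.27 log units; within the scatter), a gap that stays within the scatter. Compound 3 `O=C1OC[C@H](Cc2ccccc2)[C@H]1Cc1ccc(O)cc1` differs from compound 2 in one place: 4-hydroxyphenyl in place of 2-fluorophenyl on a saturated chain carbon bound to a saturated ring carbon. Going by the values given here, no measured step covers this exchange; the single step seen, a 1.8-fold higher number from compound 1 to compound 2 (0.27 log units; within the scatter), trades one ring substituent for another without leaving the scatter. Nothing in these two numbers argues for a move beyond the scatter in this assay, so the expected step is a 1.0-fold lower number from compound 2 to compound 3 (0.01 log units; within the scatter). Compound 3 is therefore estimated at 70000 nM, with a range from 25000 nM to 200000 nM.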

Compound 3, half-maximal effective concentration: 88000 nM
The estimate for compound 3 lay 1.3-fold (0.10 log units) below the measured number; the measured number falls inside the stated range.
By their numbers in this assay, from the lowest: compounds 1, 2 and 3 (each within the scatter of the next, the first and the last beyond it).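

On the saturated chain carbon bound to a saturated ring carbon, 4-hydroxyphenyl in place of 2-fluorophenyl gives a 1.2-fold higher number from compound 2 to compound 3 (0.09 log units; within the scatter) in this assay. The exchange at this place therefore brings in a hydrogen-bond donor and a hydrogen-bond acceptor, which 2-fluorophenyl lacks, without a step beyond the scatter. No supporting measurement explains this result.

Going by these compounds, whether an aromatic amine or a carboxylic acid on this phenyl group would give a step beyond the scatter remains open. So does the outcome of a longer chain at this place.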